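The compounds below may be only part of what the source reports. "The series", "measured", "known", "first", "only" and "open" are said of these compounds alone.

Measured compounds:
- compound 1, `COC(c1cc(Cl)c2c(c1Cl)C(=O)N(Cc1c(C)cc(C)[nH]c1=O)CC2)C1CCOCC1`: 3.4; 3.5 (2 entries)
- compound 2, `Cc1cc(C)c(CN2CCc3c(Cl)cc([C@@H](C)CO)c(Cl)c3C2=O)c(=O)[nH]1`: 2.5
- compound 3, `Cc1cc(C)c(CN2CCc3c(Cl)cc(-c4c(C)noc4C)c(Cl)c3C2=O)c(=O)[nH]1`: 3.1

In a physicochemical assay for lipophilicity, at pH 7.4 (on this read-out lower numbers stand for lower lipophilicity and higher numbers for higher lipophilicity), compound 3 gives 3.1, the highest of the two single numbers recorded; the nearest is compound 2, which gives 2.5. Compound 1, with two entries, gives 3.4; 3.5 (2 entries). Among the compounds with values here, the one step within this set that can be read cleanly is a number 0.60 log units higher from compound 2 to compound 3 (beyond the scatter), where the 3,5-dimethyl-1,2-oxazol-4-yl group replaced the 1-(hydroxymethyl)ethyl group on an aromatic carbon.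

Compound 4, `Cc1cc(C)c(CN2CCc3c(Cl)cc([C@H](CO)[C@@H]4CCCO4)c(Cl)c3C2=O)c(=O)[nH]1`, is not yet measured. Its change from compound 3 is a group of 8 heavy atoms (6 carbon, 2 oxygen; one five-membered non-aromatic ring with 1 hetero atom) in place of a group of 7 heavy atoms (5 carbon, 1 nitrogen, 1 oxygen; one five-membered aromatic ring with 2 hetero atoms), on an aromatic carbon. The entering group keeps the hydroxymethyl seen in compound 2 and adds a five-membered non-aromatic ring with one oxygen, so compound 4 should sit between compound 2 and compound 3 in this assay. The expected step is a number 0.20 log units lower from compound 3 to compound 4 (within the scatter), within the scatter. For compound 4 the estimate is 2.9, in the range 2.5 to 3.3.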

Compound 4, distribution coefficient: 2.4
The estimate for compound 4 lay 0.50 log units above the measured number; measured number below the stated range.
By their numbers in this assay, from the lowest: compounds 4 and 2 (each within the scatter of the next); then compound 3.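

In this assay, the change at this aromatic carbon gives a number 0.70 log units lower from compound 3 to compound 4 (beyond the scatter), so a saturated side chain carrying oxolan-2-yl and hydroxymethyl does not sit close to the 3,5-dimethyl-1,2-oxazol-4-yl group on this scale. The second step, a number 0.10 log units lower from compound 2 to compound 4 (within the scatter), shows that oxolan-2-yl in place of methyl on that chain does not separate these two compounds. Repeat readings of one compound in this assay lie close together: the several entries of compound 1 in this assay, 3.4; 3.5 (2 entries)

Compound 2 and compound 4 both carry the hydroxymethyl and both give lower numbers than compound 3, but the compounds shown cannot tell whether that group sets the number, as none has the oxolan-2-yl ring without it. Going by these compounds, how a carboxylic acid or an amine in place of the hydroxymethyl would read remains open.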